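The source may hold more compounds than are shown below. What is called first, only, known or untested is meant among the compounds shown, and "the series" means these compounds.

Compound 1 `COc1cc(NC(C)CCCNC(=O)NCC2CCCCC2)c2ncccc2c1` was tested in a functional assay on CCRF-CEM cells (Homo sapiens), read by MTT assay, with a stated time of 72 h (a higher number here means a weaker inhibitor, a lower number a stronger inhibitor), where compound 1 gives 22000 nM. Among the three measured compounds it holds the highest number. Compound 3 `COc1cc(NC(C)CCCNC(=O)N(C2CCCCC2)C2CCCCC2)c2ncccc2c1` gives 13000 nM, and the two values lie within the scatter of each other. For the measured compounds named here, compound 2 `COc1cc(NC(C)CCCNC(=O)NCc2ccncc2)c2ncccc2c1` gives 2900 nM, and the step of a 7.6-fold lower number from compound 1 to compound 2 (0.88 log units; beyond the scatter) is the only measured step; it concerns a different change from the one considered here.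

Compound 4 `COc1cc(NC(C)CCCNC(=O)NC2CCCCC2)c2ncccc2c1` has not yet been measured. The change from compound 1 reads (cyclohexyl in place of cyclohexylmethyl on an amide-type nitrogen). Going by the values given here, no measured pair shows this same change, so nothing bears on it directly; what the set offers is that compound 1 and compound 3, which differ in what sits on the amide-type nitrogen, give values within the scatter of each other. On that basis the expected step is a 1.1-fold lower number from compound 1 to compound 4 (0.04 log units; within the scatter), that is, no step beyond the scatter. The estimated value for compound 4 is 20000 nM, with a range from 7000 nM to 60000 nM.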

Compound 4, half-maximal inhibitory concentration: 36000 nM
The estimate for compound 4 lay 1.8-fold (0.26 log units) below the measured number, and the stated range covers the measured number.
By their numbers in this assay, from the lowest: compound 2; then compounds 3, 1 and 4 (each within the scatter of the next, the first and the last beyond it).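

In this assay, the shortening from cyclohexylmethyl to cyclohexyl on the amide-type nitrogen gives a 1.6-fold higher number from compound 1 to compound 4 (0.21 log units; within the scatter), so this change does not separate the two compounds. Other changes on the same nitrogen do register: hydrogen in place of cyclohexyl gives a 2.8-fold higher number from compound 3 to compound 4 (0.44 log units; beyond the scatter), and cyclohexyl in place of (pyridin-4-yl)methyl gives a 12-fold higher number from compound 2 to compound 4 (1.09 log units; beyond the scatter), the largest step in the set. Nothing available explains why these steps differ in size.

The compounds shown leave open whether a benzyl group on the amide-type nitrogen would match compound 2 at 2900 nM, which would indicate whether the ring nitrogen of the pyridine matters. They also leave open how a pyridin-4-yl group bound directly to that nitrogen, or a 2-(pyridin-4-yl)ethyl group there, would read.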